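Ethyl in Place of Acetamido on a Ring Nitrogen

The source may hold more compounds than are shown below. What is called first, only, known or untested is meant among the compounds shown, and "the series" means these compounds.

Compound 1 `CC(=O)NN1C(=O)/C(=C/c2ccccc2)SC1=S` was tested in an assay for inhibition of LL-diaminopimelate aminotransferase, chloroplastic (Arabidopsis thaliana) (on this read-out lower numbers stand for stronger inhibition and higher numbers for weaker inhibition), and is recorded there only as "not active" (no number reported), so no number places it among the others. Compound 2 `N=C1NC(=O)/C(=C/c2ccc(-c3ccc([N+](=O)[O-])cc3Br)o2)S1` gives 85000 nM in this assay. Compound 3 `COc1ccc(/C=C2\SC(=S)N(NC(C)=O)C2=O)cc1` reaches only a limit of this assay, > 200000 nM; this is the limit of > 200000 nM in this assay, at which 1 of the 3 values shown sits. Compound 4 `CCN1C(=O)/C(=C/c2ccccc2)SC1=S` carries the change (ethyl in place of acetamido on an amide-type nitrogen in a ring). Within the data shown here, no measured step matches this change, and compound 1 itself has no number, so no direction can be read from the data; the shared core is weak throughout, and compound 4 is expected to stay weak as well. The estimate for compound 4 in this assay is 150000 nM, in the range 50000 nM to 500000 nM, with a limit rather than a number the likelier outcome.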

Compound 4, half-maximal inhibitory concentration: > 200000 nM
Compound 4 ended at the assay's limit; the forecaster's own chance of this, stated with the estimate: 70%; middle value at least 1.3-fold (0.12 log units) away from the limit.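

Compound 4 gives > 200000 nM as a limit of the assay and not a number. Compound 1 has no number either, so no step can be read between compound 1 and compound 4. Going by these compounds, whether ethyl or acetamido on the amide-type nitrogen in the ring gives stronger inhibition stays open.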